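A few compounds are considered here, and "the series" means these few. Any claim that something is new, unique, unknown or untested is made for them only; others in the source may bear on it.

Compound 1 `C=CC(=O)Nc1cccc(Oc2nc(Nc3ccn(C)n3)nc3c2CSCC3)c1`: 18600 nM
Compound 2 `CC/C=C/C(=O)Nc1cccc(Oc2nc(Nc3ccn(C)n3)nc3c2CSCC3)c1`: 36800 nM
Compound 3 `CCC/C=C/C(=O)Nc1cccc(Oc2nc(Nc3ccn(C)n3)nc3c2CSCC3)c1`: 8190 nM

In a functional assay on A549 cells (Homo sapiens) for antiproliferative activity, read by MTT assay, with a stated time of 72 h (on this read-out lower numbers stand for stronger inhibition and higher numbers for weaker inhibition), compound 1 stands second highest of these three numbers: its nearest neighbour is a 2.0-fold higher number from compound 1 to compound 2 (0.30 log units; within the scatter), and its furthest is a 2.3-fold lower number from compound 1 to compound 3 (0.36 log units; beyond the scatter). Compound 4 `C=CC(=O)Nc1cccc(Oc2nc(Nc3cccc(OC)c3)nc3c2CSCC3)c1` differs from compound 1 in one place: 3-methoxyphenyl in place of 1-methyl-1H-pyrazol-3-yl on a nitrogen on an aromatic ring. For the measured compounds named here, no measured step touches this nitrogen. The steps that exist all alter the chain on a carbonyl carbon, the largest being a 4.5-fold lower number from compound 2 to compound 3 (0.65 log units; beyond the scatter), and even that was modest. Nothing measured therefore guides this change, and a step of modest size in either direction in this assay cannot be ruled out. Compound 4 is expected to give 9000 nM, with a range from 1500 nM to 45000 nM, which would be a 2.1-fold lower number from compound 1 to compound 4 (0.32 log units; beyond the scatter).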

Compound 4, half-maximal inhibitory concentration: 10100 nM
The estimate for compound 4 lay 1.1-fold (0.05 log units) below the measured number; measured number inside the range.
By their numbers in this assay, from the lowest: compounds 3, 4, 1 and 2 (each within the scatter of the next, the first and the last beyond it).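

Changing the group on this nitrogen from 1-methyl-1H-pyrazol-3-yl to 3-methoxyphenyl gives a 1.8-fold lower number from compound 1 to compound 4 (0.27 log units; within the scatter) in this assay. So this nitrogen accepts a larger, all-carbon aromatic ring in place of the pyrazole without a change that can be told from the scatter. No measurement here explains this result.

Going by these compounds, what remains open is whether a plain phenyl, or a phenyl bearing a carboxylic acid or an amine, would behave the same on this nitrogen. It is also unknown whether 3-methoxyphenyl would give a similar result with the pent-1-en-1-yl chain of compound 3.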